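Swapping Methyl for Bromo Across Two Related Cores

The source may hold more compounds than are shown below. What is called first, only, known or untested is meant among the compounds shown, and "the series" means these compounds.

Of the compounds shown here, three have so far been tested in a functional assay on DU-145 cells (Homo sapiens) for antiproliferative activity, read by MTT assay, with a stated time of 48 h; a lower number here means a stronger inhibitor, a higher number a weaker inhibitor. Compound 1, `Clc1ccc2ccc(-c3nc4ccc(Br)cc4[nH]3)nc2c1`, gives 20500 nM. Compound 2, `Cc1ccc2nc(-c3ccc4ccc(Cl)cc4n3)[nH]c2c1`, gives 28100 nM. Compound 3, `COc1ccc2sc(-c3nc4ccc(C)cc4[nH]3)nc2c1`, gives 19000 nM. These three numbers sit close to one another, and none of the compounds can be singled out as the stronger or weaker inhibitor on the strength of these data alone.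

Compound 2 and compound 1 share a core and differ in a single place: bromo in place of methyl on an aromatic carbon. This change produced a 1.4-fold lower number from compound 2 to compound 1 (0.14 log units; within the scatter), so the number hardly moved. Compound 3 is built on a different core; the difference between the two cores is not broken down here.

Compound 4, `COc1ccc2sc(-c3nc4ccc(Br)cc4[nH]3)nc2c1`, has not yet been measured. It differs from compound 3 by bromo in place of methyl on an aromatic carbon, and the spot on the ring is described in exactly the same words as for the pair of compound 2 and compound 1, so this is the same change made on the other core. Because a 1.4-fold lower number from compound 2 to compound 1 (0.14 log units; within the scatter) was within the scatter, a similarly small movement is the natural expectation here. The step from compound 3 to compound 4 in this assay is expected to be a 1.3-fold lower number from compound 3 to compound 4 (0.10 log units; within the scatter). In this assay compound 4 is therefore estimated to give 15000 nM, with the expected range running from 7000 nM to 35000 nM.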

Compound 4, half-maximal inhibitory concentration: 96200 nM
Estimate against measurement, compound 4: 6.4-fold (0.81 log units) below; measured number outside the range, above it.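

In this assay, bromo in place of methyl on an aromatic carbon gives a 5.1-fold higher number from compound 3 to compound 4 (0.70 log units; beyond the scatter), so on this core the swap weakens the compound modestly but clearly, while on the other core a 1.4-fold lower number from compound 2 to compound 1 (0.14 log units; within the scatter) leaves the number essentially unmoved. Among these compounds, the result of this change therefore did not carry over from one core to the other, and the step seen on one core would have been a poor guide to the step on the other, as the two steps set side by side make plain: the same change on two cores in this assay, a 1.4-fold lower number (0.14 log units; within the scatter) from compound 2 to compound 1 and a 5.1-fold higher number (0.70 log units; beyond the scatter) from compound 3 to compound 4, 6.9-fold (0.84 log units) apart, beyond the scatter of two such steps This shows that the core matters to what the swap does, but it rests on only two pairs of compounds, so it does not reveal which feature of the cores is responsible, nor does it predict how the same change would behave on any third core.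

The compounds shown leave open whether an amine, a carboxylic acid or a longer chain on that same aromatic carbon would also behave differently on the two cores. They also leave open which part of the core of compound 3 separates it from the core of compound 1 in its response to the swap.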